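The source may hold more compounds than are shown below. What is called first, only, known or untested is meant among the compounds shown, and "the series" means these compounds.

Compound 3 `Cc1nc(-c2nc3ccccc3n2Cc2ccccc2)sc1C(=O)Nc1ccccc1` carries the lowest of the two plain numbers in a functional assay on MCF7 cells (Homo sapiens) for cytotoxicity, read by MTT assay, with a stated time of 24 h (on this read-out lower numbers stand for stronger inhibition and higher numbers for weaker inhibition), where compound 3 gives 3960 nM. Its nearest neighbour is compound 2 `Cc1nc(-c2nc3ccccc3n2Cc2ccccc2)sc1C(=O)NC(C)C`, which in this assay gives 6640 nM; the step of a 1.7-fold lower number from compound 2 to compound 3 (0.22 log units; within the scatter) sits within the scatter, so the two cannot be ranked. Compound 1 `CCOC(=O)c1sc(-c2nc3ccccc3n2Cc2ccccc2)nc1C` gives only a limit in this assay, > 20000 nM, and that limit is the limit of > 20000 nM in this assay, at which 1 of the 3 values shown sits. From this limit the amides stand apart: an at least 3.0-fold lower number from compound 1 to compound 2 (0.47 log units; beyond the scatter) and an at least 5.0-fold lower number from compound 1 to compound 3 (0.70 log units; beyond the scatter).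

Compound 4 `Cc1nc(-c2nc3ccccc3n2Cc2ccccc2)sc1C(=O)N1CCCCC1` differs from compound 3 in one place: piperidin-1-yl in place of anilino on a carbonyl carbon. The amide stays, but its nitrogen now carries the ring and no hydrogen. Going by the values given here, the one step that changes the group on the amide nitrogen, a 1.7-fold lower number from compound 2 to compound 3 (0.22 log units; within the scatter), was within the scatter, while both steps from the ester to an amide were beyond it. The expected step from compound 3 to compound 4 in this assay is therefore a 1.1-fold higher number from compound 3 to compound 4 (0.06 log units; within the scatter), not beyond the scatter. For compound 4 the estimated value in this assay is 4500 nM, with a range from 1800 nM to 12000 nM.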

Compound 4, half-maximal inhibitory concentration: > 20000 nM
Compound 4: only a limit was reported; the forecaster's own chance of this, stated with the estimate: 10%; middle value at least 4.4-fold (0.64 log units) from the limit.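

At this place, on a carbonyl carbon, being an amide is not enough to hold the activity, as the piperidin-1-yl change gives an at least 5.0-fold higher number from compound 3 to compound 4 (0.70 log units; beyond the scatter) and an at least 3.0-fold higher number from compound 2 to compound 4 (0.47 log units; beyond the scatter). Going by these compounds alone, the earlier step between the anilino and isopropylamino amides stayed within the scatter, so this is the first sign that the group on the amide nitrogen can matter in this assay. Compound 4 gives only a limit, the same one as compound 1, so the step between them cannot be read: the limit of > 20000 nM in this assay, at which 2 of the 4 values shown sit.

Piperidin-1-yl removes the amide hydrogen and the aromatic ring together, and the compounds shown cannot separate these two changes. A cyclohexylamino group, which keeps the amide hydrogen on a non-aromatic ring, would help to tell them apart.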